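Taking the ethyl off compound 3

A few compounds are considered here, and "the series" means these few. Any claim that something is new, unique, unknown or untested is made for them only; others in the source may bear on it.

Three related compounds have been measured in a physicochemical assay for lipophilicity; on this read-out higher numbers stand for higher lipophilicity and lower numbers for lower lipophilicity. Compound 1 `CCn1nc(Cn2nnc(-c3ccccn3)n2)cc1C` gives 2.08, compound 2 `CCn1nc(Cn2nnnc2-c2ccccn2)cc1C` gives 1.34, and compound 3 `CCn1nc(Cn2nnc(Cc3ccccc3)n2)cc1C` gives 2.88, the highest of the three.

The next compound, compound 4 `Cc1cc(Cn2nnc(Cc3ccccc3)n2)n[nH]1`, differs from compound 3 in a single place: hydrogen in place of ethyl on an aromatic nitrogen. This puts hydrogen in place of ethyl on an aromatic nitrogen.

Among the measured compounds shown here, only one measured step bears on this, and only loosely. It is a number 0.80 log units higher from compound 1 to compound 3 (beyond the scatter), and it puts benzyl in place of pyridin-2-yl on an aromatic carbon, so the ethyl is not involved. For the measured compounds named here, no measured pair of compounds loses an ethyl, which makes the direction of the coming change a judgement rather than a reading from the data. That one step serves only as a guide to size. On that guide, the expected change in this assay is a modest fall beyond the scatter, a number 0.88 log units lower from compound 3 to compound 4 (beyond the scatter). The estimated value for compound 4 is 2, with an expected range from 1.6 to 2.4.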

Compound 4, partition coefficient: 2.5
The estimate for compound 4 lay 0.50 log units below the measured number, and the stated range ends below it.
By their numbers in this assay, from the lowest: compound 2; then compound 1; then compound 4; then compound 3.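

In this assay, hydrogen in place of ethyl on the aromatic nitrogen gives a number 0.38 log units lower from compound 3 to compound 4 (beyond the scatter). Among the compounds shown here, this is the first measured change at this position, and it shows that the read-out responds to this swap, moving down when the ethyl leaves and nothing else in the molecule changes. Nothing measured here explains the size of this step.

Going by these compounds, only ethyl and hydrogen appear on this nitrogen, so it remains open whether a methyl, a propyl chain or a longer alkyl chain would place the number between or beyond these two compounds. The swap also appears only in the benzyl series, which leaves open whether it would give a similar step in compounds carrying pyridin-2-yl in place of benzyl.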